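This account rests on a few compounds, and the source may have more. Where it says the series, first, only, none or still open, it means among the compounds named here.

Measured in a functional assay on HCT-8 cells (Homo sapiens) for cytotoxicity, read by MTT assay, with a stated time of 72 h; a lower number here means a stronger inhibitor, a higher number a weaker inhibitor:
- compound 1 `C=CC(C)(C/C=C(\C)CCC=C(C)C)c1ccc(OCc2ccccc2)c(OCc2ccccc2)c1`: "not active" (no number reported)
- compound 2 `C=CC(C)(C/C=C(\C)CCC=C(C)C)c1ccc(OCc2ccccc2)c(O)c1`: "not active" (no number reported)
- compound 3 `C=CC(C)(C/C=C(\C)CCC=C(C)C)c1ccc(O)c(OC)c1`: 14.5 ug/mL

Compound 2 has no single number to stand on. In this assay compound 2 is reported as "not active" (no number reported), and compound 1 is likewise reported as "not active" (no number reported). Both carry benzyloxy, so only compound 3 gives a real number, at 14.5 ug/mL.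

The next compound to test is compound 4 `C=CC(C)(C/C=C(\C)CCC=C(C)C)c1ccc(OC)c(O)c1`, which differs from compound 2 in one place: hydrogen in place of phenyl on a saturated chain carbon bound to an oxygen on an aromatic ring. Hydrogen takes the place of phenyl on a saturated chain carbon bound to an oxygen on an aromatic ring, which turns benzyloxy into methoxy.

For the measured compounds named here, no measured pair here shows this change directly, so its size cannot be read from the data. The expected direction in this assay is a gain, from no reported activity to a measurable but modest value. Such a result would resemble compound 3 at 14.5 ug/mL, the only numerical guide available. Compound 4 could still return no number at all, as compound 2 did. For compound 4 the estimated value is 15 ug/mL, with an expected range from 6 ug/mL to 40 ug/mL.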

Compound 4, half-maximal inhibitory concentration: > 25 ug/mL
Compound 4 was reported as a limit; the forecaster's own chance of this, stated with the estimate: 25%; middle value at least 1.6-fold (0.22 log units) away from the limit.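

In this assay, compound 4 gives > 25 ug/mL, which is a limit and not a number. Compound 2 is reported only as "not active", so no step can be read between compound 2 and compound 4. The compounds shown leave open how much, if at all, replacing benzyloxy with methoxy changes cytotoxicity.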